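Compound 1 to compound 4: bromo for trifluoromethyl

This account rests on a few compounds, and the source may have more. Where it says the series, first, only, none or still open, it means among the compounds named here.

The notes start from compound 1 (`N#Cc1ccc(NC(=O)c2ccc(C(F)(F)F)cc2O)cc1`), which gives 1440 nM in a functional assay on KG-1 cells (Homo sapiens) for cytotoxicity, read by luminescence and CellTiter-Glo, with a stated time of 3 days (a higher number here means a weaker inhibitor, a lower number a stronger inhibitor), as its reading. Compound 2 (`O=C(Nc1cccc(C(F)(F)F)c1)c1cc(F)ccc1O`) gives 1010 nM in this assay and lies within the scatter of compound 1. Compound 3 (`N#Cc1ccc(NC(=O)c2ccc3cccnc3c2O)c(Cl)c1`) gives 3670 nM in this assay and this number stands higher than that of compound 1 by more than the scatter, which makes compound 1 the stronger of that pair.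

Compound 4 (`N#Cc1ccc(NC(=O)c2ccc(Br)cc2O)cc1`) has not yet been measured. It carries bromo in place of trifluoromethyl on an aromatic carbon, para to a large group and meta to a hydroxy group. The counted change is bromo in place of trifluoromethyl on an aromatic carbon and the remainder of the structure stays as in compound 1.

Going by the values given here, no measured pair differs in one place only, so this exchange has no direct precedent. Among the compounds with values here, the only guide is the spread of the three readings, from compound 2 at 1010 nM to compound 3 at 3670 nM across compounds that differ in several places. The expected step of a 1.1-fold lower number from compound 1 to compound 4 (0.04 log units; within the scatter) in this assay is estimated to lie within the scatter. In this assay the estimated value for compound 4 is 1300 nM with an expected range from 500 nM to 3500 nM as a working figure.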

Compound 4, half-maximal inhibitory concentration: 1450 nM
Compound 4: the middle estimate sits 1.1-fold (0.05 log units) below what was measured; the range from low to high includes it.
By their numbers in this assay, from the lowest: compounds 2, 1 and 4 (each within the scatter of the next); then compound 3.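

In this assay, the series now has a comparison that differs in one place only, and it reads a 1.0-fold higher number from compound 1 to compound 4 (0.00 log units; within the scatter), with bromo in place of trifluoromethyl. At this position, on an aromatic carbon meta to a hydroxy group and para to a large group, this read-out does not tell the two groups apart, although bromo enters with 1 heavy atom where trifluoromethyl leaves with 4 heavy atoms. Nothing measured here bears on why the two groups read alike.

The compounds shown leave open whether an amine, a carboxylic acid or a methoxy group at this position would also stay within the scatter of compound 1 in this assay, or would give a step beyond it. Also open, from the compounds shown here alone, is whether the same exchange would read alike on the core of compound 3, and this single pair supports no general rule for the series.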